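A few compounds are considered here, and "the series" means these few. Any claim that something is new, unique, unknown or untested is made for them only; others in the source may bear on it.

Measured compounds:
Compound 1, `Cc1[nH]nc(N)c1-c1cc(C(F)(F)F)cc(C(F)(F)F)c1`: in an assay on Sf9 cells for inhibition of mitogen-activated protein kinase kinase kinase 14 (Homo sapiens), read by ADP-Glo, with a stated time of 60 min (a lower number here means a stronger inhibitor, a higher number a weaker inhibitor), compound 1 gives > 100000 nM, which is a limit of the assay rather than a number.
Compound 2, `Cc1nn(C(=O)C2CCC2)c(N)c1-c1ccc(Cl)c(Cl)c1`: in this assay compound 2 gives 2900 nM.

Going by the values given here, compound 2 therefore holds the only real number in this assay so far. The value of compound 1 is the limit of > 100000 nM in this assay, at which 1 of the 2 values shown sits. Compound 2 cannot be placed above or below any other measured compound. It simply sets the one reference point from which the next step is followed.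

Compound 3, `Cc1nn(C(=O)OC(C)(C)C)c(N)c1-c1ccc(Cl)c(Cl)c1`, has not yet been measured. It differs from compound 2 in one place: tert-butoxy in place of cyclobutyl on a carbonyl carbon. Put another way, the cyclobutylcarbonyl on the ring nitrogen of compound 2 becomes a tert-butoxycarbonyl in compound 3, while the rest of the molecule stays the same.

Among the compounds with values here, no step between measured compounds is available to calibrate a change of this kind, so the expectation rests on the closeness of the two structures alone. The expected outcome in this assay is a step within or only just beyond the usual scatter, leaning if anything toward a weaker inhibitor, a 1.2-fold higher number from compound 2 to compound 3 (0.08 log units; within the scatter). Compound 3 is accordingly estimated at 3500 nM, with a range from 1000 nM to 12000 nM.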

Compound 3, half-maximal inhibitory concentration: > 100000 nM
Compound 3 gave a limit, no number (the forecaster's own chance of this, stated with the estimate: 5%); middle value at least 28-fold (1.45 log units) from the limit.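

In this assay compound 3 gives > 100000 nM, which is a limit of the assay and not a number. Placing tert-butoxy instead of cyclobutyl on the carbonyl carbon, with the rest of the molecule unchanged, gives an at least 34-fold higher number from compound 2 to compound 3 (1.53 log units; beyond the scatter), so this one change at this position is enough to take away the measurable inhibition seen with compound 2. The same limit now applies to most of the compounds shown: the limit of > 100000 nM in this assay, at which 2 of the 3 values shown sit.

The compounds shown leave open which part of the change matters, since the cyclobutyl ring leaves and an oxygen enters in the same step, and the two cannot be told apart from this pair alone. A cyclopentyl or a plain methyl on the same carbonyl carbon, or a dimethylamino group in that place, would be needed to show whether the loss follows the ring, the oxygen or something else about the tert-butoxy group.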